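The source may report more compounds than this note shows. Statements on the series, on what has been measured and on what is new or still open speak of the compounds shown alone.

The measured compounds, each with its result in the cytotoxicity test:

compound 1, `Cc1cc(C)cc(S(=O)(=O)c2c(C(=O)NC3CC4(CCNCC4)C3)[nH]c3ccc(Cl)cc23)c1`: 24200 nM
compound 2, `Cc1cc(C)cc(S(=O)(=O)c2c(C(=O)NC3CC4(CCN(C(=O)OC(C)(C)C)CC4)C3)[nH]c3ccc(Cl)cc23)c1`: 133000 nM
compound 3, `Cc1cc(C)cc(S(=O)(=O)c2c(C(=O)NC3CC4(CNC4)C3)[nH]c3ccc(Cl)cc23)c1`: 28600 nM

All three were tested in a toxicity assay on MT4 cells (Homo sapiens) for cytotoxicity, read by MTT assay, with a stated time of 7 days; on this read-out higher numbers stand for lower toxicity in this test and lower numbers for higher toxicity in this test. Compound 1 gives 24200 nM in this assay, and compound 3 gives 28600 nM. The two cores differ in this way: a group of 7 heavy atoms (6 carbon, 1 nitrogen; one four-membered non-aromatic ring of carbon only, one four-membered non-aromatic ring with 1 hetero atom) in place of a group of 9 heavy atoms (8 carbon, 1 nitrogen; one four-membered non-aromatic ring of carbon only, one six-membered non-aromatic ring with 1 hetero atom), on an amide-type nitrogen. The step of a 1.2-fold higher number from compound 1 to compound 3 (0.07 log units; within the scatter) shows that this exchange of the ring system on the amide-type nitrogen makes no difference that can be told from repeat measurements.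

Compound 2 carries a protecting group on the ring amine: tert-butoxycarbonyl in place of hydrogen on an amine nitrogen in a ring. Here the step is a 5.5-fold higher number from compound 1 to compound 2 (0.74 log units; beyond the scatter), a modest loss of toxicity, and compound 2 gives 133000 nM.

Compound 4, `Cc1cc(C)cc(S(=O)(=O)c2c(C(=O)NC3CC4(C3)CN(C(=O)OC(C)(C)C)C4)[nH]c3ccc(Cl)cc23)c1`, has not yet been measured. It stands to compound 3 as compound 2 stands to compound 1: tert-butoxycarbonyl in place of hydrogen on an amine nitrogen in a ring. The two changes are of the same kind but not the same, since in compound 2 the group sits on a six-membered non-aromatic ring with 1 nitrogen, three ring bonds from the ring atom that bears two fused rings, while in compound 4 it sits on a four-membered non-aromatic ring with 1 nitrogen, two ring bonds from that atom.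

Because compound 1 and compound 3 stand so close in a 1.2-fold higher number from compound 1 to compound 3 (0.07 log units; within the scatter), and because the same kind of change gave a 5.5-fold higher number from compound 1 to compound 2 (0.74 log units; beyond the scatter), the step of a 4.2-fold higher number from compound 3 to compound 4 (0.62 log units; beyond the scatter) is expected for compound 4. The smaller ring in compound 4 leaves some uncertainty. Compound 4 is therefore estimated at 120000 nM in this assay, expected between 45000 nM and 320000 nM.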

Compound 4, half-maximal cytotoxic concentration: > 224000 nM
Compound 4 ended at the assay's limit; the forecaster's own chance of this, stated with the estimate: 15%; middle value at least 1.8-fold (0.27 log units) from the limit.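

In this assay compound 4 gives > 224000 nM, which is a limit of the assay and not a number. Tert-butoxycarbonyl in place of hydrogen on the ring amine nitrogen moves the number the same way on both cores, with an at least 7.8-fold higher number from compound 3 to compound 4 (0.89 log units; beyond the scatter), so the direction of this change carries over from the core of compound 1 to the core of compound 3, and the two steps can be set side by side only as far as this: the same change on two cores in this assay, a 5.5-fold higher number (0.74 log units; beyond the scatter) from compound 1 to compound 2 and an at least 7.8-fold higher number (0.89 log units; beyond the scatter) from compound 3 to compound 4; the limit leaves it open whether they differ What this does not show is how large the step on the core of compound 3 really is or whether the two cores respond to the same degree, since compound 4 stands at the end of the measurable range: the limit of > 224000 nM in this assay, at which 1 of the 4 values shown sits.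

The compounds shown leave open whether a smaller group on the same ring nitrogen, such as acetyl or methyl, would shift the number in the same direction on both cores. They also leave open whether the change would carry over in the same way on a core in which the chlorine is replaced by fluorine or the two methyl groups on the aromatic ring are absent.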